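Swapping Isopropoxy for Trifluoromethoxy on a Benzylamide

The compounds below may be only part of what the source reports. "The series", "measured", "known", "first", "only" and "open" are said of these compounds alone.

Compound 1 `CC(C)Oc1ccc(CNC(=O)c2ccc(C(C)(C)C)cc2)cc1`: 170 nM
Compound 2 `CC(C)(C)c1ccc(C(=O)NCc2ccc(NC(=O)C(F)(F)F)cc2Cl)cc1`: 14 nM

In an assay on HeLa cells with Bile acid receptor (Homo sapiens) as the target, read by a luciferase reporter, with a stated time of 24 h (on this read-out lower numbers stand for an effect already at smaller amounts and higher numbers for an effect only at larger amounts of compound), compound 1 gives 170 nM, the higher of the two numbers. Compound 2 gives 14 nM, and that gap lies beyond the scatter. Compound 3 `CC(C)(C)c1ccc(C(=O)NCc2ccc(OC(F)(F)F)cc2)cc1` has not yet been measured. It differs from compound 1 by trifluoromethyl in place of isopropyl on an oxygen on an aromatic ring. For the measured compounds named here, no measured pair shows this exact change, so the expectation rests on the change itself: a small step, possibly towards a lower number, but likely not beyond the scatter. For compound 3 the expected step is a 1.4-fold lower number from compound 1 to compound 3 (0.15 log units; within the scatter). Compound 3 is estimated at 120 nM, within a range from 40 nM to 400 nM.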

Compound 3, half-maximal effective concentration: 160 nM
The estimate for compound 3 lay 1.3-fold (0.12 log units) below the measured number; measured number inside the range.
By their numbers in this assay, from the lowest: compound 2; then compounds 3 and 1 (each within the scatter of the next).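

In this assay, trifluoromethyl in place of isopropyl on an oxygen on an aromatic ring gives a 1.1-fold lower number from compound 1 to compound 3 (0.03 log units; within the scatter), the first step seen at this place. Isopropoxy and trifluoromethoxy therefore read alike here, so this exchange leaves the number unmoved on the core of compound 1. No measurement shown offers an explanation for this match. Going by these compounds, whether an amine, a carboxylic acid or a longer chain such as butoxy at this place would move the number stays open. So does whether the same exchange would read alike on another core.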